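A few compounds are considered here, and "the series" means these few. Any claim that something is new, unique, unknown or untested is made for them only; others in the source may bear on it.

Within the data shown here, compound 1 `O=C(Nc1cccc(-n2cc(-c3ccncc3)c(-c3ccc(Cl)c(O)c3)n2)c1)Nc1cccc(C(F)(F)F)c1` gives the highest of the three numbers so far in a functional assay on NCI-H226 cells (Homo sapiens) for inhibition, read by sulforhodamine B assay, with a stated time of 48 h (a higher number here means a weaker inhibitor of growth, a lower number a stronger inhibitor of growth), namely 7350 nM. Compound 2 `O=C(Nc1cccc(-n2cc(-c3ccncc3)c(-c3ccc(Cl)c(O)c3)n2)c1)Nc1ccc(Cl)c(Cl)c1` gives 1510 nM, and compound 3 `COc1cc(-c2nn(-c3cccc(NC(=O)Nc4cccc(C(F)(F)F)c4)c3)cc2-c2ccncc2)ccc1Cl` gives 1380 nM. Compound 4 `O=C(Nc1cccc(-n2cc(-c3ccncc3)c(-c3ccc(Cl)c(O)c3)n2)c1)Nc1cc(C(F)(F)F)cc(C(F)(F)F)c1` differs from compound 1 by trifluoromethyl in place of hydrogen on an aromatic carbon. Of the measured steps, the one on the same urea-bound ring, a 4.9-fold lower number from compound 1 to compound 2 (0.69 log units; beyond the scatter), bears most directly on it; the other, a 5.3-fold lower number from compound 1 to compound 3 (0.73 log units; beyond the scatter), sits on a different part of the shared core. Both were modest and beyond the scatter in the same direction, so a modest lowering is expected for compound 4 in this assay, a 2.5-fold lower number from compound 1 to compound 4 (0.39 log units; beyond the scatter). The estimate for compound 4 is 3000 nM, with a range from 1000 nM to 9000 nM.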

Compound 4, concentration for 50% growth inhibition: 1240 nM
Estimate against measurement, compound 4: 2.4-fold (0.38 log units) above; low and high end bracket the measured number.
By their numbers in this assay, from the lowest: compounds 4, 3 and 2 (each within the scatter of the next); then compound 1.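

In this assay, adding a second trifluoromethyl to the urea-bound ring gives a 5.9-fold lower number from compound 1 to compound 4 (0.77 log units; beyond the scatter), so this aromatic carbon accepts a group of four heavy atoms and the number falls rather than rises. Unlike the earlier step on this ring, this change keeps the existing trifluoromethyl and only adds to it. Nothing available accounts for the lowering.

The compounds shown do not tell whether it is specific to trifluoromethyl, or whether a methyl, an amine or a carboxylic acid on this carbon would behave alike. Going by these compounds, whether it would add to the change on the oxygen also remains open.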